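Sulfonyl group swaps: working notes toward compound 4

A few compounds are considered here, and "the series" means these few. Any claim that something is new, unique, unknown or untested is made for them only; others in the source may bear on it.

Measured in a toxicity assay on Vero cells (Chlorocebus sabaeus) for cytotoxicity, read by MTT assay (on this read-out higher numbers stand for weaker inhibition and lower numbers for stronger inhibition), so far:
- compound 1 (`COC(=O)NC(=O)c1ccsc1NC(=O)c1ccc(S(=O)(=O)N2CCC(C)CC2)cc1`): 9.13 ug/mL
- compound 2 (`COC(=O)NC(=O)c1ccsc1NC(=O)c1ccc(S(=O)(=O)N2CCC(OC)CC2)cc1`): 18 ug/mL
- compound 3 (`CCN(C)S(=O)(=O)c1ccc(C(=O)Nc2sccc2C(=O)NC(=O)OC)cc1`): 10.4 ug/mL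

On these numbers compound 2 lies within the scatter of both other compounds (a 2.0-fold higher number from compound 1 to compound 2 (0.29 log units; within the scatter); a 1.7-fold lower number from compound 2 to compound 3 (0.24 log units; within the scatter)). The change to compound 4 (`COC(=O)NC(=O)c1ccsc1NC(=O)c1ccc(S(=O)(=O)NC2CCC(F)(F)CC2)cc1`) is this one ((4,4-difluorocyclohexyl)amino in place of 4-methoxypiperidin-1-yl on a sulfonyl sulfur). Swapping the whole group on a sulfonyl sulfur has so far also stayed within the scatter (a 1.1-fold higher number from compound 1 to compound 3 (0.06 log units; within the scatter)). Among the measured compounds shown here, no measured compound carries the (4,4-difluorocyclohexyl)amino group, so the range is kept wide. No step beyond the scatter is therefore expected in this assay for this change. The expected step is small (a 1.5-fold lower number from compound 2 to compound 4 (0.18 log units; within the scatter)). The estimate for compound 4 is (12 ug/mL), expected to fall between (5 ug/mL) and (28 ug/mL).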

Compound 4, half-maximal inhibitory concentration: 49 ug/mL
Compound 4: middle estimate off by 4.1-fold (0.61 log units), on the low side, and the stated range ends below it.
By their numbers in this assay, from the lowest: compounds 1, 3 and 2 (each within the scatter of the next); then compound 4.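

In this assay, a swap on the sulfonyl sulfur now gives steps beyond the scatter, all towards higher numbers (a 2.7-fold higher number from compound 2 to compound 4 (0.43 log units; beyond the scatter)) (a 4.7-fold higher number from compound 3 to compound 4 (0.67 log units; beyond the scatter)) (a 5.4-fold higher number from compound 1 to compound 4 (0.73 log units; beyond the scatter)). Against 4-methoxypiperidin-1-yl, the (4,4-difluorocyclohexyl)amino group brings a ring of carbon only, fluorine and a hydrogen-bond donor together, so this position tolerates more change in the number than the earlier swaps showed. Nothing at hand bears on the cause of this rise.

Which of these features goes with the step stays open. Cyclohexylamino without fluorine, or 4,4-difluoropiperidin-1-yl, would separate them.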